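This account rests on a few compounds, and the source may have more. Where it says the series, first, only, none or still open, it means among the compounds named here.

Measured compounds:
compound 1, `Nc1cc(N)c2nc(-c3ccccc3)c(Oc3ccc(Cl)c(Cl)c3)nc2c1`, 4070 nM
compound 2, `CCOC(=O)[C@H](CCC(=O)O)NC(=O)c1ccc(CNc2nc3cc(N)cc(N)c3nc2-c2ccccc2)cc1`, < 100000 nM

Among the compounds with values here, in a functional assay on UO-31 cells (Homo sapiens) for inhibition, read by sulforhodamine B assay, with a stated time of 48 h (on this read-out higher numbers stand for weaker inhibition of growth and lower numbers for stronger inhibition of growth), compound 1 gives 4070 nM, and this is the only number available here. For compound 2 the read-out in this assay is only a limit, < 100000 nM, not a number; this is the limit of < 100000 nM in this assay, at which 1 of the 2 values shown sits. Within the data shown here, compound 1 therefore stands alone as the sole compound with a measured value, and no step between two measured compounds can be drawn from these two entries.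

The unmeasured compound 3, `COc1ccc(Sc2nc3cc(N)cc(N)c3nc2-c2ccccc2)cc1`, keeps the shared core of compound 1 with its phenyl group and differs in a single place: (4-methoxyphenyl)sulfanyl in place of 3,4-dichlorophenoxy on an aromatic carbon. The 3,4-dichlorophenoxy group leaves and the (4-methoxyphenyl)sulfanyl group enters on the aromatic carbon next to the ring nitrogen.

Among the measured compounds shown here, with no measured step to guide the size of this exchange, the account expects compound 3 to stay close to compound 1, with a step of a 1.2-fold higher number from compound 1 to compound 3 (0.09 log units; within the scatter) that does not clearly exceed the scatter. The estimated value for compound 3 in this assay is 5000 nM, expected to lie between 1500 nM and 17000 nM.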

Compound 3, concentration for 50% growth inhibition: 4170 nM
Beside the measured number, compound 3's estimate is 1.2-fold (0.08 log units) above it, within the range that was stated.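

In this assay, within the data shown here, putting (4-methoxyphenyl)sulfanyl in place of 3,4-dichlorophenoxy gives a 1.0-fold higher number from compound 1 to compound 3 (0.01 log units; within the scatter) as the first step that can be read between two measured compounds. On this aromatic carbon, next to the ring nitrogen and ortho to a phenyl group, compound 1 and compound 3 therefore cannot be told apart, although the entering group differs from the leaving group in its linking atom and in carrying a methoxy group in place of two chlorine atoms, while the heavy-atom count stays equal. Nothing measured here gives a reason for this result.

The exchange alters the linking atom and the substituents on the outer ring together, so the compounds shown do not separate the two changes, and a 3,4-dichlorophenylsulfanyl group would be needed to do so. Going by these compounds, it also remains open whether a different kind of group at this position, such as an amine, a carboxylic acid or a longer chain, would give a value apart from those of compound 1 and compound 3.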